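This account rests on a few compounds, and the source may have more. Where it says the series, first, only, none or still open, it means among the compounds named here.

Measured in a functional assay on HCT-116 cells (Homo sapiens) for inhibition, read by colorimetric assay, with a stated time of 3 days; on this read-out lower numbers stand for stronger inhibition and higher numbers for weaker inhibition:
compound 1 `COc1ccc(NC(=O)CCCCCCNC(=O)C(O)(O)C(F)(F)F)cc1`: 4520 nM
compound 2 `O=C(CCCCCCNC(=O)C(O)(O)C(F)(F)F)Nc1nc2ccccc2o1`: 3450 nM

Compound 2 gives 3450 nM and lies within the scatter of compound 1, so the two cannot be ranked. Compound 3 `O=C(CCCCCCNC(=O)C(O)(O)C(F)(F)F)Nc1ccc(F)cc1F` keeps the shared core and differs from compound 2 as follows: 2,4-difluorophenyl in place of 1,3-benzoxazol-2-yl on an amide-type nitrogen. Among the measured compounds shown here, one measured step bears on this change: a 1.3-fold lower number from compound 1 to compound 2 (0.12 log units; within the scatter), with 1,3-benzoxazol-2-yl in place of 4-methoxyphenyl on an amide-type nitrogen. That step lies within the scatter. For the measured compounds named here, no measured compound carries 2,4-difluorophenyl, so the expectation rests on this single pair. In this assay, no step beyond the scatter is expected in either direction. The expected step is a 1.1-fold higher number from compound 2 to compound 3 (0.05 log units; within the scatter). For compound 3 the estimated value is 3900 nM, with an expected range of 1700 nM to 9000 nM.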

Compound 3, half-maximal inhibitory concentration: 18500 nM
Estimate against measurement, compound 3: 4.7-fold (0.68 log units) below, outside the stated range (above it).
By their numbers in this assay, from the lowest: compounds 2 and 1 (each within the scatter of the next); then compound 3.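

In this assay the step of a 5.4-fold higher number from compound 2 to compound 3 (0.73 log units; beyond the scatter) and the step of a 4.1-fold higher number from compound 1 to compound 3 (0.61 log units; beyond the scatter) both lie beyond the scatter, so the group on the amide-type nitrogen does affect the read-out, which the earlier swap at this nitrogen could not show. Aromatic groups are therefore not interchangeable here: 2,4-difluorophenyl gives weaker inhibition than either 1,3-benzoxazol-2-yl or 4-methoxyphenyl, while those two cannot be ranked against each other. No evidence in hand accounts for this loss.

The compounds shown leave open whether plain phenyl or 4-fluorophenyl would give numbers like those of compound 3 or like those of compound 1. They also leave open whether a 2-pyridyl group on this nitrogen would keep the inhibition seen with compound 2.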